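A few compounds are considered here, and "the series" means these few. Any claim that something is new, unique, unknown or untested is made for them only; others in the source may bear on it.

Compound 1 `COc1cc(/C=C/C(=O)c2cccc(NC(=O)c3cccs3)c2)ccc1O`: 71%
Compound 2 `COc1cc(/C=C/C(=O)c2cccc(NC(=O)c3ccco3)c2)ccc1O`: 61%

In a functional assay on HUVEC cells (Homo sapiens) for inhibition, tested at 2.5 ug/mL (a lower number here means a weaker effect, a higher number a stronger effect of the compound at the concentration tested), compound 2 gives 61%, and compound 1 gives 71%; the step of a number 10 percentage points lower from compound 1 to compound 2 (within the scatter) lies within the scatter, so the two stand together on these numbers. Compound 3 `COc1cc(/C=C/C(=O)c2cccc(N)c2)ccc1O` differs from compound 2 by hydrogen in place of (furan-2-yl)carbonyl on a nitrogen on an aromatic ring. Within the data shown here, the single measured step exchanges thiophen-2-yl for furan-2-yl on a carbonyl carbon and leaves the (furan-2-yl)carbonyl in place, so it does not bear on its removal; no measured step does. With the group removed, a weakening is expected, the step of a number 16 percentage points lower from compound 2 to compound 3 (beyond the scatter), though with wide uncertainty. Compound 3 is therefore estimated at 45%, within 20% to 70%.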

Compound 3, a percentage reported as inhibition, at one concentration (the size of the read-out at that concentration, not a potency): 20%
Compound 3: middle estimate off by 25 percentage points, on the high side; the measured number falls inside the stated range.
By their numbers in this assay, from the lowest: compound 3; then compounds 2 and 1 (each within the scatter of the next).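

In this assay, the group on the nitrogen matters: replacing (furan-2-yl)carbonyl with hydrogen gives a number 41 percentage points lower from compound 2 to compound 3 (beyond the scatter), and replacing (thiophen-2-yl)carbonyl with hydrogen gives a number 51 percentage points lower from compound 1 to compound 3 (beyond the scatter). The earlier step only exchanged one five-membered ring for another with the carbonyl kept, whereas these steps show that much of the effect at this concentration goes when the amide gives way to the plain amino group. Nothing available accounts for this loss. The compounds shown leave open whether the five-membered aromatic ring is needed, or whether a simple acetyl group or a longer alkyl chain on the carbonyl would hold the effect.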